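Cyclohexylpyrazole tetrazolyl acetamides: aryl variation at the tetrazole

The source may report more compounds than this note shows. Statements on the series, on what has been measured and on what is new or still open speak of the compounds shown alone.

Compound 2 `Cc1cc(NC(=O)Cn2nnc(-c3cc(Cl)cc(Cl)c3)n2)n(C2CCCCC2)n1` is one of two members of this series measured so far in an assay on HEK293 cells for activation of Kir3.1/Kir3.2 (Homo sapiens), read by thallium flux; a higher number here means a larger maximal response, a lower number a smaller maximal response. In this assay, going by the values given here, compound 2 gives 82%, the lower of the two numbers; its only neighbour is compound 1 `Cc1cc(NC(=O)Cn2nnc(-c3cccnc3)n2)n(C2CCCCC2)n1`, which in this assay gives 96%. Among the compounds with values here, the step of a number 14 percentage points lower from compound 1 to compound 2 (beyond the scatter) is the only measured change at the aryl position and lies beyond the scatter.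

Compound 3 `Cc1cc(NC(=O)Cn2nnc(-c3cccc(F)c3)n2)n(C2CCCCC2)n1` differs from compound 2 by 3-fluorophenyl in place of 3,5-dichlorophenyl on an aromatic carbon. Within the data shown here, no measured pair carries this exact exchange; the step from compound 1 to compound 2 concerns a different group at the same aromatic carbon, so it bears on the present change only loosely. With a single halogen in place of two on the phenyl ring, a partial return toward the number of compound 1 is plausible, but a step within the scatter is equally possible.

Compound 3 is therefore expected to give about 90% in this assay, with a range of 76% to 104%, meaning an expected step of a number 8 percentage points higher from compound 2 to compound 3 (within the scatter).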

Compound 3, largest response reached (Emax), in percent of the reference or control that the assay uses: 96%
The estimate for compound 3 lay 6 percentage points below the measured number; measured number inside the range.
By their numbers in this assay, from the lowest: compound 2; then compounds 1 and 3 (each within the scatter of the next).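

In this assay, 3-fluorophenyl in place of 3,5-dichlorophenyl on the aromatic carbon of the five-membered ring with 4 nitrogen gives a number 14 percentage points higher from compound 2 to compound 3 (beyond the scatter), so this position responds to the substitution on the phenyl ring and not only to the choice between a phenyl ring and a pyridine ring. The exchange of pyridin-3-yl for 3-fluorophenyl gives no change at the digits printed from compound 1 to compound 3 (within the scatter), which shows that a six-membered aromatic ring of carbon only can stand here without a lower number. The earlier step from compound 1 to compound 2 could not separate the loss of the ring nitrogen from the arrival of the two chlorine atoms; among these three compounds, the lower number goes with 3,5-dichlorophenyl alone.

Open, going by these compounds, is whether one chlorine on the phenyl ring behaves like the fluorine of compound 3 or the two chlorines of compound 2, and whether a phenyl ring carrying an amine or a carboxylic acid, or morpholine in place of the aryl group, is tolerated at this carbon. No available evidence accounts for the separate standing of compound 2.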